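Dimethylamino in place of hydrogen on compound 2

The source may hold more compounds than are shown below. What is called first, only, known or untested is meant among the compounds shown, and "the series" means these compounds.

Among the compounds with values here, in an ADME assay on microsomes from liver (Homo sapiens) for metabolic stability, with a stated time of 60 min, tested at 1 uM (on this read-out lower numbers stand for a less stable compound and higher numbers for a more stable compound), compound 2 (`COc1cnc2c(-c3ccnc(OC)c3)cnn2c1`) gives 2%, the lower of the two numbers measured so far. In this assay, compound 1 (`COc1cc(-c2cnn3cc(OC)c(C(C)(C)O)nc23)ccn1`) gives 66%.

Compound 3 (`COc1cc(-c2cnn3cc(OC)c(N(C)C)nc23)ccn1`) has dimethylamino in place of hydrogen on an aromatic carbon, next to the ring nitrogen and ortho to a methoxy group: dimethylamino in place of hydrogen on an aromatic carbon.

Within the data shown here, one measured step bears on this change: a number 64 percentage points lower from compound 1 to compound 2 (beyond the scatter), with hydrogen in place of 1-hydroxy-1-methylethyl on that same aromatic carbon. This large step, beyond the scatter, shows that the compound with a group at this place has the much higher number. Among the measured compounds shown here, it rests on a single pair, however, and no measured compound carries dimethylamino, so its full size cannot simply be carried over.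

A rise beyond the scatter is therefore expected, though a smaller one than in the measured step. The expected step is a number 36 percentage points higher from compound 2 to compound 3 (beyond the scatter). In this assay, compound 3 is estimated at 38%, with an expected range of 10% to 70%.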

Compound 3, percent of the compound remaining: 16%
The estimate for compound 3 lay 22 percentage points above the measured number, within the range that was stated.
By their numbers in this assay, from the lowest: compound 2; then compound 3; then compound 1.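

In this assay, a group at this aromatic carbon does not by itself carry the large gain that the earlier pair suggested: dimethylamino in place of hydrogen gives a number 14 percentage points higher from compound 2 to compound 3 (beyond the scatter) and so only a modest rise. The exchange of one group for the other at the same carbon is large, at a number 50 percentage points lower from compound 1 to compound 3 (beyond the scatter), so the identity of the group matters here and not only the presence of a group, at least across these three compounds. Nothing available explains the gap between dimethylamino and 1-hydroxy-1-methylethyl at this place.

Still open, as far as these compounds go, is whether the higher number of compound 1 goes with the hydroxy group or with the branched carbon framework around it, and a tert-butyl group on this same carbon would separate the two. Also open, from the compounds shown here alone, is whether dimethylamino stands for amines at this place in general, or whether a cyclic amine such as morpholine or a smaller one such as methylamino would read differently.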